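The source may hold more compounds than are shown below. What is called first, only, known or untested is meant among the compounds shown, and "the series" means these compounds.

Of the compounds shown here, three that share one core have been tested in an ADME assay on L02 cells (Homo sapiens) for cytotoxicity, read by MTT assay, with a stated time of 48 h; a higher number here means a weaker inhibitor, a lower number a stronger inhibitor. Compound 1, `CN(CCC#N)C[C@H]1CN(c2ccc(-n3cc(-c4ccccn4)cn3)c(F)c2)C(=O)O1`, gives > 400 ug/mL, which is a limit of the assay rather than a number. Compound 2, `O=C(OC[C@H]1CN(c2ccc(-n3cc(-c4ccccn4)cn3)c(F)c2)C(=O)O1)c1ccccc1`, gives > 400 ug/mL, again a limit. Compound 3, `COC[C@H]1CN(c2ccc(-n3cc(-c4ccccn4)cn3)c(F)c2)C(=O)O1`, gives > 400 ug/mL, also a limit. Going by the values given here, because all three values sit at the limit of > 400 ug/mL in this assay, at which 3 of the 3 values shown sit, no step between them can be read: a step that the two limits leave unreadable from compound 1 to compound 2, a step that the two limits leave unreadable from compound 1 to compound 3 and a step that the two limits leave unreadable from compound 2 to compound 3 are each hidden by the limits at both ends. Compound 3 therefore stands exactly where compound 1 and compound 2 stand, at the limit, with no ordering among the three.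

Compound 4, `CN(C)S(=O)(=O)NC[C@H]1CN(c2ccc(-n3cc(-c4ccccn4)cn3)c(F)c2)C(=O)O1`, differs from compound 3 in one place: (dimethylsulfamoyl)amino in place of methoxy on a saturated chain carbon bound to a saturated ring carbon. The three measured steps all change this same position, yet each of them is unreadable, so none gives a size to work from; what they do show is that three different groups at this position all leave the value at the limit. The step of a number no higher from compound 3 to compound 4 (the limit leaves the size open) is therefore expected to be none beyond the scatter. Compound 4 is expected to give 400 ug/mL, within a range of 150 ug/mL to 1000 ug/mL, most likely reported as a limit once more.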

Compound 4, half-maximal inhibitory concentration: 158 ug/mL
Estimate against measurement, compound 4: 2.5-fold (0.40 log units) above, within the range that was stated.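

The steps among compound 1, compound 2 and compound 3 cannot be read, so until this result the position on a saturated chain carbon bound to a saturated ring carbon had shown no visible effect on the read-out of this assay. With (dimethylsulfamoyl)amino at that position, the number does fall beyond the scatter, and it does so against each of the three other groups: methoxy (an at least 2.5-fold lower number from compound 3 to compound 4 (0.40 log units; beyond the scatter)), benzoyloxy (an at least 2.5-fold lower number from compound 2 to compound 4 (0.40 log units; beyond the scatter)) and (2-cyanoethyl)(methyl)amino (an at least 2.5-fold lower number from compound 1 to compound 4 (0.40 log units; beyond the scatter)). So this position is not indifferent in this assay, but these steps give only a minimum size because the other three compounds have no exact number: the limit of > 400 ug/mL in this assay, at which 3 of the 4 values shown sit.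

On these data alone, whether a methanesulfonylamino group, an acetylamino group or a plain amine at this position would lower the number as well, or stay at the limit, remains open. Also open, as far as these compounds go, is how far the true values of compound 1, compound 2 and compound 3 lie beyond that limit, and with it the full size of all three steps.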